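This account rests on a few compounds, and the source may have more. Where it says the series, first, only, none or still open, it means among the compounds named here.

Of the compounds shown here, three built on one shared core have been tested in a functional assay on HepG2 cells (Homo sapiens) for inhibition, read by MTT assay, with a stated time of 48 h; a lower number here means a stronger inhibitor, a higher number a weaker inhibitor. Compound 1 `Fc1ccc(/C=N/Nc2nc(-c3ccc(C(F)(F)F)cc3)cs2)cc1F` gives 14500 nM. Compound 3 `COc1cc(/C=N/Nc2nc(-c3cccc(Br)c3)cs2)cc(Br)c1OC` gives 66200 nM. Compound 2 `COc1cc(/C=N/Nc2nc(-c3ccc(C(F)(F)F)cc3)cs2)c(Br)c(Br)c1OC` reaches only a limit of the assay, reported as > 100000 nM. Compound 2 thus stands at the limit of > 100000 nM in this assay, at which 1 of the 3 values shown sits, and no actual number for it is known. Compound 4 `COc1cc(/C=N/Nc2nc(-c3ccccc3)cs2)c(Br)c(Br)c1OC` differs from compound 2 by hydrogen in place of trifluoromethyl on an aromatic carbon. Among the compounds with values here, no pair of measured compounds shows a change of this kind, and the limit for compound 2 leaves the starting point itself uncertain. Compound 4 is expected to remain weak, with an expected step of a number no higher from compound 2 to compound 4 (the limit leaves the size open) that lies within the scatter. Compound 4 is estimated at 100000 nM, in a range from 30000 nM to 300000 nM.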

Compound 4, half-maximal inhibitory concentration: 33600 nM
The estimate for compound 4 lay 3.0-fold (0.47 log units) above the measured number; measured number inside the range.
By their numbers in this assay, from the lowest: compound 1; then compounds 4 and 3 (each within the scatter of the next). At a limit, above all of these: compound 2.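

In this assay, going from 4-(trifluoromethyl)phenyl to phenyl gives an at least 2.9-fold lower number from compound 2 to compound 4 (0.47 log units; beyond the scatter). This shows that the group at this position does affect the read-out: with hydrogen in place of trifluoromethyl, a real number replaces a limit. The true size of the step remains unknown, since one end of it is only a limit: the limit of > 100000 nM in this assay, at which 1 of the 4 values shown sits.

The compounds shown leave open what an amine or a carboxylic acid at this position would do. They also leave open whether the same change would give a similar step with different groups elsewhere on the shared core.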